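Swapping One Aromatic Ring for Another

The compounds below may be only part of what the source reports. "The series", "measured", "known", "first", "only" and "open" are said of these compounds alone.

Of the compounds shown here, three have been measured so far in a functional assay; on this read-out higher numbers stand for weaker inhibition and lower numbers for stronger inhibition. Compound 1, `CC(C)=CCOc1ccc2c(c1)OC(c1cccc(F)c1)CC2=O`, gives 4280 nM. Compound 2, `CC(C)=CCOc1ccc2c(c1)OC(c1cccc(Br)c1)CC2=O`, gives 5280 nM. Compound 3, `CC(C)=CCOc1cc(O)c2c(c1)OC(c1cccc(F)c1)CC2=O`, gives 7240 nM. Nominally compound 3 carries the highest of the three numbers, but the scatter does not set it apart from the other two: the step of a 1.7-fold higher number from compound 1 to compound 3 (0.23 log units; within the scatter) and the gap to compound 2 both fall inside the usual spread of repeat measurements.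

Compound 4, `COc1ccc(C2CC(=O)c3c(O)cc(OCC=C(C)C)cc3O2)cc1`, has not yet been measured. It differs from compound 3 in one place: 4-methoxyphenyl in place of 3-fluorophenyl on a saturated ring carbon. Going by the values given here, one measured step touches the same aromatic ring, namely a 1.2-fold higher number from compound 1 to compound 2 (0.09 log units; within the scatter), where bromo stood in place of fluoro and the number stayed essentially where it was. Among the compounds with values here, no measured step replaces the entire ring, so the precedent is thin and rests on a single small change. On that precedent the expected outcome in this assay is a step no larger than the scatter, a 1.1-fold lower number from compound 3 to compound 4 (0.05 log units; within the scatter). Compound 4 is therefore estimated at 6500 nM, with a range from 2000 nM to 20000 nM that reflects the limited evidence.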

Compound 4, half-maximal inhibitory concentration: 5080 nM
The estimate for compound 4 lay 1.3-fold (0.11 log units) above the measured number, within the range that was stated.
By their numbers in this assay, from the lowest: compounds 1, 4, 2 and 3 (each within the scatter of the next).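

Going by these compounds alone, this is the first change that replaces the whole aromatic ring on the saturated ring carbon, rather than a single atom on it. In this assay the exchange of 3-fluorophenyl for 4-methoxyphenyl gives a 1.4-fold lower number from compound 3 to compound 4 (0.15 log units; within the scatter) and so cannot be told apart from no change at all. The position next to the ring oxygen therefore accepts a different aromatic group, with the fluorine gone and a methoxy group on the ring, without any shift beyond the scatter, which the earlier swap of bromo for fluoro could only hint at; nothing available here explains why the number holds steady.

All the groups seen at this carbon are still carbon-only aromatic rings with no net charge, so the compounds say nothing about whether this tolerance extends to a ring carrying an amine or a carboxylic acid, or to a non-aromatic group such as cyclohexyl. On these data alone, since all four compounds lie within the scatter of their neighbours, it also remains open which change, if any, would move the number clearly in either direction.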